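Hydrazone series: swapping the group on the amine nitrogen

The source may report more compounds than this note shows. Statements on the series, on what has been measured and on what is new or still open speak of the compounds shown alone.

Among the compounds with values here, compound 3 `CCOC(=O)C1=C(N/C=N/c2ccc([N+](=O)[O-])cc2)Nc2[nH]nc(C)c2C1c1ccc(N(C)C)cc1` stands second highest of the three numbers measured so far: in a functional assay on HepG2 cells (Homo sapiens) for inhibition, read by MTT assay, with a stated time of 48 h (a lower number here means a stronger inhibitor, a higher number a weaker inhibitor), compound 3 gives 50900 nM. Compound 1 `CCOC(=O)C1=C(N/N=C(/Br)c2ccccc2)Nc2[nH]nc(C)c2C1c1ccc(N(C)C)cc1` gives 72000 nM in this assay, and compound 2 `CCOC(=O)C1=C(N/N=C(\C#N)C(N)=O)Nc2[nH]nc(C)c2C1c1ccc(N(C)C)cc1` gives 48400 nM. All three lie within the scatter of one another: a 1.5-fold lower number from compound 1 to compound 2 (0.17 log units; within the scatter), a 1.4-fold lower number from compound 1 to compound 3 (0.15 log units; within the scatter), a 1.1-fold higher number from compound 2 to compound 3 (0.02 log units; within the scatter). Each of these steps exchanges the group on the amine nitrogen whose other neighbour is a double-bonded ring carbon, and none of them lies beyond the scatter.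

Compound 4 `CCOC(=O)C1=C(N/N=C(/C(C)=O)C(=O)OCC)Nc2[nH]nc(C)c2C1c1ccc(N(C)C)cc1` differs from compound 3 at that same place: a group of 10 heavy atoms (6 carbon, 1 nitrogen, 3 oxygen; no ring) in place of a group of 11 heavy atoms (7 carbon, 2 nitrogen, 2 oxygen; one six-membered aromatic ring of carbon only), on an amine nitrogen. The three measured steps bear on this change directly, since every one of them swaps the group on the same amine nitrogen, and every one of them was small. The expectation for compound 4 in this assay is therefore no step beyond the scatter, a 1.1-fold higher number from compound 3 to compound 4 (0.03 log units; within the scatter). Compound 4 is estimated at 55000 nM, with a range from 25000 nM to 120000 nM.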

Compound 4, half-maximal inhibitory concentration: > 100000 nM
Compound 4: only a limit was reported (the forecaster's own chance of this, stated with the estimate: 10%); middle value at least 1.8-fold (0.25 log units) away from the limit.
By their numbers in this assay, from the lowest: compounds 2, 3 and 1 (each within the scatter of the next). At a limit, above all of these: compound 4.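

In this assay compound 4 gives > 100000 nM, a limit of the assay and not a number, and the only such reading so far: the limit of > 100000 nM in this assay, at which 1 of the 4 values shown sits.

Exchange on this amine nitrogen is no longer small throughout: an at least 2.0-fold higher number from compound 2 to compound 4 (0.31 log units; beyond the scatter), and this first step beyond the scatter at this place joins two groups that both have no ring. The other two steps, an at least 1.9-fold higher number from compound 3 to compound 4 (0.29 log units; that floor lies within the scatter) and an at least 1.3-fold higher number from compound 1 to compound 4 (0.14 log units; that floor lies within the scatter), separate nothing on their own.

From the compounds shown here alone, how far compound 4 lies past its limit remains open, and with it whether it truly differs from compound 1 and compound 3. Also open, going by these compounds, is how a carboxylic acid or a plain amine in the group on this nitrogen would read.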